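The source may report more compounds than this note shows. Statements on the series, on what has been measured and on what is new or still open speak of the compounds shown alone.

Going by the values given here, compound 2 `CC(C)(C)C1=NN(c2ccc(Cl)cc2)C(c2cccc(O)c2)C1` is the only member of this small series with a number: in an assay on isolated protein for inhibition of protein kinase C zeta type (Homo sapiens), with a stated time of 4 min (on this read-out lower numbers stand for stronger inhibition and higher numbers for weaker inhibition), compound 2 gives 5300 nM. Compound 1 `CC(C)(C)C1=NN(c2ccc(Cl)cc2)C(c2ccc(C#N)cc2)C1` has no result in this assay: in this assay compound 1 is "not determined" (no result reported). Compound 3 `CC(C)(C)C1=NN(c2ccc(Cl)cc2)C(c2ccc(O)c(Cl)c2)C1` differs from compound 2 in one place, (3-chloro-4-hydroxyphenyl in place of 3-hydroxyphenyl on a saturated ring carbon), that is, 3-chloro-4-hydroxyphenyl in place of 3-hydroxyphenyl on a saturated ring carbon. Among the compounds with values here, no pair of measured compounds shows what such a change does here, so the step is expected to stay small and its direction is open. Compound 3 is therefore estimated at 4000 nM, within 1500 nM to 12000 nM, an expected step of a 1.3-fold lower number from compound 2 to compound 3 (0.12 log units; within the scatter).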

Compound 3, half-maximal inhibitory concentration: 700 nM
Beside the measured number, compound 3's estimate is 5.7-fold (0.76 log units) above it; measured number below the stated range.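

In this assay, replacing 3-hydroxyphenyl with 3-chloro-4-hydroxyphenyl on this saturated ring carbon gives a 7.6-fold lower number from compound 2 to compound 3 (0.88 log units; beyond the scatter) and so shows that the number responds to what this phenyl ring carries, which compound 2 alone could not show. Nothing given here explains the shift. The change adds a chlorine and alters the hydroxyl's place together, so the compounds shown cannot separate the two, as 4-hydroxyphenyl and 3-chlorophenyl might. Also open, from the compounds shown here alone, is how an amine or a carboxylic acid on that ring would fare.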